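The source may hold more compounds than are shown below. What is called first, only, known or untested is meant among the compounds shown, and "the series" means these compounds.

Compound 1 `Cc1nc(-c2ccc(C(F)(F)F)cc2)sc1CNc1ccc(CCCC(=O)O)cc1` belongs to a pair of agonists tested in a functional assay on CHO cells for agonist activity at Free fatty acid receptor 1 (Homo sapiens); on this read-out lower numbers stand for an effect already at smaller amounts and higher numbers for an effect only at larger amounts of compound. In this assay compound 1 gives < 10000 nM, which is a limit of the assay rather than an exact number. Compound 2 `CC(C)(Oc1ccc(NCc2cccc(Oc3ccccc3)c2)cc1)C(=O)O` is the other member of the pair; in this assay compound 2 gives < 10000 nM, again a limit. So far the data hold only (the limit of < 10000 nM in this assay, at which 2 of the 2 values shown sit), so no measured step between compounds is available, and where compound 1 stands relative to compound 2 cannot be told.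

Compound 3 `Cc1nc(-c2ccc(C(F)(F)F)cc2)sc1CNc1ccc([C@H]2C[C@@H]2C(N)=O)cc1` is the next compound to be measured. Compared with compound 1 it carries 2-carbamoylcyclopropyl in place of 3-carboxypropyl on an aromatic carbon. Within the data shown here, with no measured step in hand, the step that the limit leaves unreadable from compound 1 to compound 3 is an expectation only, and it may well lie within the usual scatter. For compound 3 a value of 2000 nM is estimated, with a range from 200 nM to 15000 nM, and the assay may again report only a limit.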

Compound 3, half-maximal effective concentration: 4.47 nM
For compound 3 the middle estimate is 450-fold (2.65 log units) above the measured one, and the stated range ends above it.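

Among these compounds, no step from compound 1 to compound 3 can be read, because the value for compound 1 is a limit and not an exact number: the limit of < 10000 nM in this assay, at which 2 of the 3 values shown sit. The compounds shown leave open how large the effect of 2-carbamoylcyclopropyl in place of 3-carboxypropyl is in this assay, and which part of the new group matters.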